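A few compounds are considered here, and "the series" means these few. Any claim that something is new, unique, unknown or untested is made for them only; others in the source may bear on it.

Compound 1, `COC/C1=C/C[C@](C)(CCC=C(C)C)/C=C/[C@@H](OC(=O)C=C(C)C)[C@](C)(OC)/C=C/C1=O`: 14600 nM. Compound 2, `CC(C)=CCC[C@]1(C)/C=C/[C@@H](OC(=O)C=C(C)C)[C@](C)(O)/C=C/C(=O)/C(C(=O)O)=C\C1`: > 10000 nM.

In a functional assay on SW480 cells (Homo sapiens) for antiproliferative activity, read by MTT assay, with a stated time of 48 h (on this read-out lower numbers stand for stronger inhibition and higher numbers for weaker inhibition), compound 1 gives 14600 nM. Compound 2 stands at a limit: in this assay compound 2 reports > 10000 nM, which is the limit of > 10000 nM in this assay, at which 1 of the 2 values shown sits, and not a number. For the measured compounds named here, compound 1 and compound 2 differ in more than one place, so no step between them is known; the two values show only that neither compound is a strong inhibitor in this assay. Compound 3, `CC(C)=CCC[C@]1(C)/C=C/[C@@H](OC(=O)C=C(C)C)[C@](C)(O)/C=C/C(=O)/C(CN2CCN(C)CC2)=C\C1`, is not yet measured. It is compound 2 with (4-methylpiperazin-1-yl)methyl in place of carboxy on a double-bonded ring carbon. Going by the values given here, no measured step covers this change, so the expectation for compound 3 is loose. The step of an at least 1.2-fold lower number from compound 2 to compound 3 (0.09 log units; that floor lies within the scatter) is expected to be a modest gain, of a size not far beyond the scatter. Compound 3 is therefore estimated at 8000 nM in this assay, with a range from 2500 nM to 25000 nM.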

Compound 3, half-maximal inhibitory concentration: 800 nM
For compound 3 the middle estimate is 10-fold (1.00 log units) above the measured one; measured number below the stated range.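

In this assay, (4-methylpiperazin-1-yl)methyl in place of carboxy on this double-bonded ring carbon gives an at least 12-fold lower number from compound 2 to compound 3 (1.09 log units; beyond the scatter). For the compounds shown here, this is the first single change, and it shows that the group on this ring carbon can move the value well beyond the scatter, which compound 1 and compound 2 could not show. Compound 2 stands at a limit and not a number, so the step has only a floor: the limit of > 10000 nM in this assay, at which 1 of the 3 values shown sits.

The compounds shown leave open whether this step needs the whole (4-methylpiperazin-1-yl)methyl group, or whether a smaller amine such as dimethylaminomethyl or a morpholin-4-ylmethyl group on the same carbon would give a similar value. They also leave open how much of the step comes from the carboxy leaving and how much from the piperazine entering.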